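The compounds below may be only part of what the source reports. "The series", "measured", "known", "first", "only" and "open" are said of these compounds alone.

Measured compounds:

Compound 1 `CCc1nc(-c2cccc(F)c2)c(C(=O)N2CCN(c3cccc(OC)c3)CC2)o1` — in a functional assay on HL-60 cells (Homo sapiens) for inhibition, read by MTT assay, with a stated time of 72 h (a higher number here means a weaker inhibitor, a lower number a stronger inhibitor), compound 1 gives 201 nM.
Compound 2 `COc1cccc(N2CCN(C(=O)c3oc(C)nc3-c3cccc(F)c3)CC2)c1` — in this assay compound 2 gives "not active" (no number reported).
Compound 3 `COc1cccc(N2CCN(C(=O)c3oc(C)nc3-c3ccccc3F)CC2)c1` — in this assay compound 3 gives 56.1 nM.

Compound 2 stands apart from the other two in that no number at all was reported for it; it was simply recorded as not active, so its place on the scale of this assay cannot be fixed more closely than that. Compound 1 and compound 3 each carry a number, and both share the same core with compound 2, differing elsewhere.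

Compound 4 `Cc1ccc(C)c(N2CCN(C(=O)c3oc(C)nc3-c3cccc(F)c3)CC2)c1` has not yet been measured. It differs from compound 2 at one place only: 2,5-dimethylphenyl in place of 3-methoxyphenyl on an amine nitrogen in a ring. The ring-bound group that leaves has one oxygen; the one that enters is carbon only. Within the data shown here, nothing in the measured set tracks this particular exchange, so no step of known size can be borrowed for it. Given that compound 2 showed no measurable effect in this assay, the expectation for compound 4 is that it stays weak, with a substantial chance that the read-out again comes back as a limit rather than a number. The estimate for compound 4 in this assay is 8000 nM, expected to fall between 1500 nM and 40000 nM.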

Compound 4, half-maximal inhibitory concentration: 204 nM
For compound 4 the middle estimate is 39-fold (1.59 log units) above the measured one, and the stated range ends above it.
By their numbers in this assay, from the lowest: compound 3; then compounds 1 and 4 (each within the scatter of the next).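

In this assay compound 4 gives 204 nM while compound 2 gives "not active" (no number reported) and so no size can be read for the step between them. No measured evidence bears on this result. From the compounds shown here alone, what stays open is how the exchange of 3-methoxyphenyl for 2,5-dimethylphenyl would act on a compound with a reported number, such as compound 3.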